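The source may report more compounds than this note shows. Statements on the series, on what has been measured and on what is new or still open speak of the compounds shown alone.

Measured so far:
- compound 1 `COc1cccc(/C=C/C(=O)Nc2cc(C(=O)c3cc(OC)c(OC)c(OC)c3)ccc2OC)c1`; in a functional assay on COLO 205 cells (Homo sapiens) for cytotoxicity, read by MTT assay, with a stated time of 72 h (on this read-out higher numbers stand for weaker inhibition and lower numbers for stronger inhibition), compound 1 gives 5100 nM
- compound 2 `C#CCOc1cccc(/C=C/C(=O)Nc2cc(C(=O)c3cc(OC)c(OC)c(OC)c3)ccc2OC)c1`; compound 2 gives 13400 nM
- compound 3 `COc1cc(/C=C/C(=O)Nc2cc(C(=O)c3cc(OC)c(OC)c(OC)c3)ccc2OC)ccc1F`; compound 3 gives 11800 nM

Compound 2 holds the highest number of the three. Its gap to compound 3 is a 1.1-fold lower number from compound 2 to compound 3 (0.06 log units; within the scatter), so these two cannot be ordered; the remaining gap is a 2.6-fold higher number from compound 1 to compound 2 (0.42 log units; beyond the scatter), a modest step that is beyond the scatter.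

The next compound, compound 4 `C#CCOc1cccc(/C=C/C(=O)Nc2cc(C(=O)c3cc(OC)c(OC)c(OC)c3)cc(OC)c2OC)c1`, differs from compound 2 by methoxy in place of hydrogen on an aromatic carbon. This change sits on the shared core, whereas both measured steps beyond the scatter, a 2.6-fold higher number from compound 1 to compound 2 (0.42 log units; beyond the scatter) and a 2.3-fold higher number from compound 1 to compound 3 (0.36 log units; beyond the scatter), concern the other aryl ring. Going by the values given here, no measured pair tests a substituent on the core ring, so the change has no direct precedent; the two modest steps only show that single-group changes here have so far moved the number by small amounts.

The expectation is therefore a step of a 1.1-fold lower number from compound 2 to compound 4 (0.05 log units; within the scatter), within the scatter or at most modest, with the direction uncertain. Compound 4 is estimated at 12000 nM, in the range 5000 nM to 30000 nM.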

Compound 4, half-maximal inhibitory concentration: 11200 nM
For compound 4 the middle estimate is 1.1-fold (0.03 log units) above the measured one, and the stated range covers the measured number.
By their numbers in this assay, from the lowest: compound 1; then compounds 4, 3 and 2 (each within the scatter of the next).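

In this assay, methoxy in place of hydrogen gives a 1.2-fold lower number from compound 2 to compound 4 (0.08 log units; within the scatter) on the shared core, at an aromatic carbon ortho to a methoxy group and meta to two large groups. Going by these compounds alone, this is the first measured change on the shared core rather than on the other aryl group, and this carbon carries the added methoxy without a step beyond the scatter, so far with the 3-(propargyloxy)phenyl group in place. No measured evidence bears on this result.

The compounds shown do not tell whether the same addition would stay within the scatter alongside the aryl group of compound 1, which has the lowest number here. They also leave open whether an amine, a hydroxyl or a longer chain such as ethoxy at this carbon would move the number beyond the scatter.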